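The source may report more compounds than this note shows. Statements on the series, on what has been measured and on what is new or still open speak of the compounds shown alone.

Measured so far in an assay on isolated protein for agonist activity at melatonin receptor type 1C (Xenopus laevis), read by spectrophotometry; a lower number here means a smaller maximal response, a higher number a larger maximal response:
compound 1, `CCCC(=O)NCCCc1cc(OC)ccc1F`, gives 100%
compound 2, `CCC(=O)NCCCc1ccc(OC)c(F)c1`, gives 78%

Compound 2 holds the lower of the two numbers in this assay; compound 1 sits above it by a margin beyond the usual scatter. For the measured compounds named here, no single-point step between these two measured compounds can be drawn, since they differ in more than one place, so the two values stand on their own.

The next compound to be run is compound 3, `CCCC(=O)NCCCc1ccc(OC)c(F)c1`. Relative to compound 2 the change is methyl in place of hydrogen on a saturated chain carbon, two bonds along the chain from a carbonyl carbon. Nothing measured in the series isolates this particular change, so no step size is known for it. The expectation is a small shift upward in this assay, most likely not beyond the scatter: the step from compound 2 to compound 3 is estimated at a number 8 percentage points higher from compound 2 to compound 3 (within the scatter). Compound 3 is therefore expected to give about 86%, within a range from 66% to 104%.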

Compound 3, largest response reached (reported as efficacy), in percent of the reference or control that the assay uses: 73%
Compound 3: the middle estimate sits 13 percentage points above what was measured; the range from low to high includes it.
By their numbers in this assay, from the lowest: compounds 3 and 2 (each within the scatter of the next); then compound 1.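

In this assay, the series now has its first single-point step at this position, and it reads a number 5 percentage points lower from compound 2 to compound 3 (within the scatter) for methyl in place of hydrogen on a saturated chain carbon, two bonds along the chain from a carbonyl carbon. On the core of compound 2, the change from propanoyl to propylcarbonyl therefore gives no distinguishable shift in maximal response, so this carbon accepts the added methyl with the response retained. Nothing available bears on why the response holds across this change.

Whether the position keeps accepting growth stays open, since a longer chain such as pentanoyl, a branched isobutyryl group or an amine on this carbon lies outside the compounds shown. Also open, going by these compounds, is whether the same change behaves alike on the core of compound 1, as this single step comes from one core only.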